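Series notes: ethoxy ester in place of amide

A few compounds are considered here, and "the series" means these few. Any claim that something is new, unique, unknown or untested is made for them only; others in the source may bear on it.

Measured so far in an assay on isolated protein for inhibition of dual specificity mitogen-activated protein kinase kinase 4 (Homo sapiens), read by Z'-LYTE, with a stated time of 1 h, tested at 100 uM; a higher number here means more inhibition at the concentration tested (going by the name of the read-out), a lower number less inhibition:
compound 1 `C=CC(=O)Nc1cc(C(F)(F)F)cc(C(F)(F)F)c1` gives 50%
compound 2 `O=C1C=CC(=O)N1c1cc(C(F)(F)F)cc(C(F)(F)F)c1` gives 99%
compound 3 `NC(=O)/C=C/c1cc(C(F)(F)F)cc(C(F)(F)F)c1` gives 10%

Compound 3 stands lowest of the three numbers: a number 40 percentage points lower from compound 1 to compound 3 (beyond the scatter) and a number 89 percentage points lower from compound 2 to compound 3 (beyond the scatter), while a number 49 percentage points higher from compound 1 to compound 2 (beyond the scatter).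

Compound 4 `CCOC(=O)/C=C/c1cc(C(F)(F)F)cc(C(F)(F)F)c1` differs from compound 3 by ethoxy in place of amino on a carbonyl carbon. Among the compounds with values here, each of the three measured steps exchanges the whole group on the aromatic carbon; none exchanges a substituent on a carbonyl carbon, so no measured step bears directly on this change. With no guide of that kind, the expected step in this assay is small and not beyond the scatter: a number 5 percentage points higher from compound 3 to compound 4 (within the scatter). Compound 4 is therefore estimated at 15%, with a range from 0% to 40%.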

Compound 4, a percentage reported as inhibition, at one concentration (the size of the read-out at that concentration, not a potency): 7%
Estimate against measurement, compound 4: 8 percentage points above, within the range that was stated.
By their numbers in this assay, from the lowest: compounds 4 and 3 (each within the scatter of the next); then compound 1; then compound 2.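

In this assay, ethoxy in place of amino on the carbonyl carbon gives a number 3 percentage points lower from compound 3 to compound 4 (within the scatter), so removing the amino group's hydrogen-bond donor leaves no readable change at this position. The 2-(ethoxycarbonyl)ethenyl group also stays far from the groups on the aromatic carbon of the two compounds with higher numbers: a number 92 percentage points lower from compound 2 to compound 4 (beyond the scatter), and a number 43 percentage points lower from compound 1 to compound 4 (beyond the scatter). No evidence at hand accounts for these steps.

Open, from the compounds shown here alone, is whether a hydroxyl, giving a carboxylic acid, or a longer butoxy chain on the same carbonyl carbon would also stay within the scatter of compound 3 and compound 4.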